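A few compounds are considered here, and "the series" means these few. Any claim that something is new, unique, unknown or untested is made for them only; others in the source may bear on it.

Going by the values given here, in an ADME assay (liver) for metabolic stability, with Liver microsome (Homo sapiens) as the target, using microsomes (a lower number here means that the compound disappears faster, a higher number that the compound lasts longer), compound 1 `CC(C)c1nc2ccccn2c1C(=O)NCc1ccc(-c2ccccc2)cc1` gives 0.527 h as the only true number so far. Compound 2 `Cc1nc2ccc(Cl)cn2c1C(=O)NCc1ccc(-c2ccccc2)cc1` reads > 2 h and that is a limit of the assay, not a number. Compound 3 `CCc1nc2cc(Cl)ccn2c1C(=O)NCc1ccc(-c2ccc[nH]2)cc1` reads > 2 h and that too is a limit, not a number.

Compound 4 `CCc1nc2cc(Cl)ccn2c1C(=O)NCc1ccc(-n2cc3c(c2)CCCC3)cc1` differs from compound 3 in one place, on an aromatic carbon of a six-membered aromatic ring of carbon only, para to a large group. There the 1H-pyrrol-2-yl leaves and a larger group enters: a group of 9 heavy atoms (8 carbon, 1 nitrogen; one five-membered aromatic ring with 1 hetero atom, one six-membered non-aromatic ring of carbon only) in place of a group of 5 heavy atoms (4 carbon, 1 nitrogen; one five-membered aromatic ring with 1 hetero atom), on an aromatic carbon is the full count.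

Among the compounds with values here, no two measured compounds differ in just one place. Compound 1 with 0.527 h shows that shorter half-lives do occur in this set, so a modest fall is expected for compound 4. There is also a fair chance that compound 4 will read another limit. The estimated step of an at least 1.3-fold lower number from compound 3 to compound 4 (0.12 log units; that floor lies within the scatter) is only rough, as it starts from a limit. For compound 4 the estimated half-life is 1.5 h with an expected range from 0.6 h to 3.5 h in this assay once measured.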

Compound 4, half-life: 0.455 h
Compound 4: middle estimate off by 3.3-fold (0.52 log units), on the high side; the measured number lies below the stated range.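

In this assay, replacing the 1H-pyrrol-2-yl with the larger group of 9 heavy atoms gives an at least 4.3-fold lower number from compound 3 to compound 4 (0.64 log units; beyond the scatter), so the group on this aromatic carbon, para to a large group, can clearly change how long a compound lasts. Going by these compounds alone, no two earlier compounds differed in just one place, so none of them could link a change in half-life to a single position. Compound 3 reads > 2 h, which is a limit and not a number, and the step can only be given as a minimum because of that limit: the limit of > 2 h in this assay, at which 2 of the 4 values shown sit.

The change adds a six-membered non-aromatic ring, increases size and removes the hydrogen-bond donor of the 1H-pyrrol-2-yl all at once, and these compounds cannot separate those features. As far as these compounds go, how a morpholine ring or a carboxylic acid would behave at this place also remains open.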